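The source may report more compounds than this note shows. Statements on the series, on what has been measured and on what is new or still open speak of the compounds shown alone.

Of the compounds shown here, three have been measured in a functional assay (aorta) with Oryctolagus cuniculus as the target; on this read-out lower numbers stand for tighter binding and higher numbers for weaker binding. Compound 1 `COc1cc(C(C)=O)ccc1OCCCN1CCC(C(c2ccccc2)c2ccc(F)cc2)CC1` gives 6.31 nM, and compound 2 `COc1cc(C(C)=O)ccc1OCCCN1CCC(C(c2ccc(F)cc2)C2CCCCC2)CC1` gives 5.01 nM. Among the compounds with values here, the only step between two measured compounds that differ in one place is a 1.3-fold lower number from compound 1 to compound 2 (0.10 log units; within the scatter). Compound 3 `NC(=O)c1ccc(OCCCN2CCC(C(c3ccc(F)cc3)c3ccc(F)cc3)CC2)cc1` gives 31.6 nM, the highest of the three numbers: compound 1 lies nearest to it and compound 2 furthest, both separated from compound 3 by gaps beyond the scatter.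

The step under consideration leads from compound 3 to compound 4 `Fc1ccc(C(c2ccc(F)cc2)C2CCN(CCCCc3ccccc3)CC2)cc1`. The change is benzyl in place of 4-carbamoylphenoxy on a saturated chain carbon, three bonds along the chain from an amine nitrogen in a ring. Within the data shown here, no measured step touches this part of the molecule; the one step that was measured concerns the saturated chain carbon bound to an aromatic carbon and a saturated ring carbon, and its size was within the scatter. The number for compound 4 in this assay is therefore estimated close to that of compound 3, with a wide range, and the expected step is a 1.6-fold lower number from compound 3 to compound 4 (0.20 log units; within the scatter). Compound 4 is expected to give 20 nM, between 5 nM and 80 nM.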

Compound 4, dissociation constant: 2.51 nM
Beside the measured number, compound 4's estimate is 8.0-fold (0.90 log units) above it; the whole stated range lies above it.
By their numbers in this assay, from the lowest: compounds 4, 2 and 1 (each within the scatter of the next, the first and the last beyond it); then compound 3.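

In this assay, within the data shown here, the group at this place on the chain proves able to move the number well beyond the scatter: a 13-fold lower number from compound 3 to compound 4 (1.10 log units; beyond the scatter), whereas the only earlier step, a 1.3-fold lower number from compound 1 to compound 2 (0.10 log units; within the scatter), lay within the scatter and concerned another place in the molecule. With benzyl entering, compound 4 reaches 2.51 nM, so a low number here does not require a hydrogen-bond donor or acceptor in the entering group. Nothing available accounts for the size of this step.

The change removes the oxygen and the carbamoyl group together, so the compounds shown leave open which of the two, or the shift from 4-carbamoylphenoxy to benzyl as a whole, carries the step. Plain phenoxy, a carboxylic acid on the ring in place of the carbamoyl group, or a longer chain ending in phenyl would each bear on that question.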